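Aminopyridine in Place of Difluorophenyl on the Thiazole Series

The compounds below may be only part of what the source reports. "The series", "measured", "known", "first", "only" and "open" are said of these compounds alone.

Two compounds of the shared core carry numbers in an in vitro functional assay on HEK285-7 cells for antagonist activity at prostaglandin D2 receptor 2 (Homo sapiens), read by BRET and beta-arrestin recruitment; on this read-out lower numbers stand for stronger inhibition and higher numbers for weaker inhibition. Compound 1, `O=C(O)Cc1sc(COc2ccc(Cl)cc2)nc1-c1ccc(Cl)cc1`, gives 370 nM in this assay. Compound 2, `O=C(O)Cc1sc(C(c2ccc(F)cc2)c2ccc(F)cc2)nc1-c1cc(F)cc(F)c1`, gives 340 nM in this assay. The two values lie within the scatter of each other, so no order between compound 1 and compound 2 can be read from them; compound 2 simply stands on the lower of the two numbers shown without that gap meaning anything.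

Compound 3, `Cc1cc(-c2nc(C(c3ccc(F)cc3)c3ccc(F)cc3)sc2CC(=O)O)cnc1N`, has not yet been measured. It differs from compound 2 in one place: 6-amino-5-methylpyridin-3-yl in place of 3,5-difluorophenyl on an aromatic carbon. Among the compounds with values here, no step between two measured compounds touches the group on that carbon, so nothing here shows how this assay answers to such an exchange. The expectation is therefore a step from compound 2 to compound 3 of a 1.2-fold higher number from compound 2 to compound 3 (0.07 log units; within the scatter), not beyond the scatter in either direction, with a wide band of uncertainty. On that basis compound 3 is estimated at 400 nM in this assay, within a range from 100 nM to 1600 nM.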

Compound 3, half-maximal inhibitory concentration: > 100000 nM
Compound 3: no number, only a limit; the forecaster's own chance of this, stated with the estimate: 5%; at least 250-fold (2.39 log units) between middle value and limit.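

The aromatic carbon next to the ring nitrogen does not tolerate every six-membered aromatic group in this assay: 6-amino-5-methylpyridin-3-yl in place of 3,5-difluorophenyl gives an at least 290-fold higher number from compound 2 to compound 3 (2.46 log units; beyond the scatter). The reading for compound 3 is a limit of the assay and not a number, so this step has no upper end: the limit of > 100000 nM in this assay, at which 1 of the 3 values shown sits.

The two groups match in heavy-atom count and net charge, and each is a single six-membered aromatic ring, so these shared features alone do not preserve the response at this position; the groups differ in the hetero atom, the hydrogen-bond donor and the hydrogen-bond acceptors.

The ring nitrogen, the amine and the methyl enter together in this one step, and the compounds shown do not separate their contributions. On these data alone, how this assay would answer to an unsubstituted pyridin-3-yl, or to a phenyl carrying only an amine or only a methyl, remains open, as does any reading for this series with a pyridine ring at this carbon that lies inside the range of the assay.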